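A few compounds are considered here, and "the series" means these few. Any claim that something is new, unique, unknown or untested is made for them only; others in the source may bear on it.

Measured compounds in a functional assay on the whole organism (strain albino) with Mus musculus as the target, with a stated time of 0.5 h; on this read-out lower numbers stand for an effect already at smaller amounts and higher numbers for an effect only at larger amounts of compound:
- compound 1 `COc1ccc(/C=C2/N=C(c3ccccc3)N(C(=O)c3ccc(Cl)cc3)NC2=O)cc1` gives 100 mg/kg
- compound 2 `O=C1NN(C(=O)c2ccc(Cl)cc2)C(c2ccccc2)=N/C1=C/c1ccccc1` gives 100 mg/kg
- compound 3 `Cc1ccc(/C=C2/N=C(c3ccccc3)N(C(=O)c3ccc(Cl)cc3)NC2=O)cc1` gives 100 mg/kg

Compound 3 stands level with compound 1 and compound 2 in this assay; the step of no change at the digits printed from compound 1 to compound 3 (within the scatter) and the step of no change at the digits printed from compound 2 to compound 3 (within the scatter) both lie within the scatter, as does the step of no change at the digits printed from compound 1 to compound 2 (within the scatter) between the other two.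

Compound 4 `Cc1ccc(/C=C2/N=C(c3ccccc3)N(C(=O)c3ccc(C)cc3)NC2=O)cc1` differs from compound 3 by methyl in place of chloro on an aromatic carbon, that is, (4-chlorophenyl)carbonyl becomes (4-methylphenyl)carbonyl. Among the measured compounds shown here, none of the measured steps involves the chloro group or this ring; all three concern the ring that carries methoxy, hydrogen or methyl, and each of them left this assay unchanged within the scatter. For the measured compounds named here, the data therefore give no sign that a single small change on an aromatic carbon moves the read-out here, but they also contain no step of the same kind as the one from compound 3 to compound 4. On this basis compound 4 is expected to show no change beyond the scatter, a step of no change at the digits printed from compound 3 to compound 4 (within the scatter). The estimate for compound 4 is 100 mg/kg, with a range from 50 mg/kg to 200 mg/kg.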

Compound 4, dose for half-maximal effect: 100 mg/kg
For compound 4 middle estimate and measured number coincide at the digits printed; low and high end bracket the measured number.
By their numbers in this assay, from the lowest: compounds 1, 2, 3 and 4 (each within the scatter of the next).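

In this assay, among the compounds shown here, there is no change at the digits printed from compound 3 to compound 4 (within the scatter) for the first step that touches the (4-chlorophenyl)carbonyl group rather than the ring carrying methoxy, hydrogen or methyl. Methyl in place of chloro, on an aromatic carbon para to a large group, thus leaves the read-out within the scatter at this second site as well, so the flat picture now covers both aromatic rings. Nothing measured here gives a reason for this result.

What the compounds shown leave open is whether an amine, a carboxylic acid or a longer chain at this position would move the read-out. With all four compounds within the scatter of one another, they also leave open which part of the shared core, if any, the read-out depends on.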